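This account rests on a few compounds, and the source may have more. Where it says the series, first, only, none or still open, it means among the compounds named here.

Compound 1 `Cc1ccc(-c2cn(-c3cc4ccc(O)c(C)c4oc3=O)nn2)cc1` gives 23200 nM in a functional assay on MCF7 cells (Homo sapiens) for antiproliferative activity (a higher number here means a weaker inhibitor, a lower number a stronger inhibitor), the lowest of the three numbers. Compound 2 `CC(=O)Oc1ccc2cc(-n3cc(/C=C/c4ccccc4)nn3)c(=O)oc2c1C` gives 28500 nM in this assay, within the scatter of compound 1, while compound 3 `CC(=O)Oc1ccc2cc(-n3cc(-c4cc5ccccc5[nH]4)nn3)c(=O)oc2c1C` gives 76100 nM in this assay, beyond that scatter. Compound 4 `Cc1c(O)ccc2cc(-n3cc(-c4c[nH]c5ccccc45)nn3)c(=O)oc12` differs from compound 1 in that (1H-indol-3-yl in place of 4-methylphenyl on an aromatic carbon). For the measured compounds named here, only one measured step bears on this change: a 2.7-fold higher number from compound 2 to compound 3 (0.43 log units; beyond the scatter), where an indolyl group also enters, though through a different attachment and in place of a different group. A modest rise of the number, toward weaker inhibition, is therefore expected, as a 1.9-fold higher number from compound 1 to compound 4 (0.29 log units; within the scatter). Compound 4 is estimated at 45000 nM in this assay, with a range from 15000 nM to 130000 nM.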

Compound 4, half-maximal inhibitory concentration: 8170 nM
Estimate against measurement, compound 4: 5.5-fold (0.74 log units) above, and the stated range ends above it.
By their numbers in this assay, from the lowest: compound 4; then compounds 1 and 2 (each within the scatter of the next); then compound 3.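

In this assay, 1H-indol-3-yl in place of 4-methylphenyl on this aromatic carbon of the five-membered aromatic ring with 3 nitrogen gives a 2.8-fold lower number from compound 1 to compound 4 (0.45 log units; beyond the scatter), so the larger group with one hydrogen-bond donor is accepted here. The earlier indolyl step, a 2.7-fold higher number from compound 2 to compound 3 (0.43 log units; beyond the scatter), ran the other way, so an indolyl group entering does not set a single direction across the compounds shown. Nothing available accounts for this difference.

Open, on these data alone, is how a 1-methylindol-3-yl group or an aminophenyl group would fare on this carbon, and thus whether the indole hydrogen matters.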